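Removing one methoxy group across the series

The source may hold more compounds than are shown below. What is called first, only, known or untested is meant among the compounds shown, and "the series" means these compounds.

Compound 1 `COc1ccc(-c2cc(/C=C/C(=O)c3ccc(N)cc3)[nH]n2)cc1` gives 4190 nM in a functional assay on RXF 393 cells (Homo sapiens) for inhibition, read by sulforhodamine B assay, with a stated time of 48 h; on this read-out lower numbers stand for stronger inhibition of growth and higher numbers for weaker inhibition of growth. Compound 2 `COc1ccc(-c2cc(/C=C/C(=O)c3ccc(N)cc3)[nH]n2)cc1OC` gives 5120 nM in this assay. Compound 3 `COc1cc(C(=O)/C=C/c2cc(-c3cc(OC)c(OC)c(OC)c3)n[nH]2)cc(OC)c1OC` gives 2670 nM in this assay; the difference between its core and that of compound 2 is not broken down here. For the measured compounds named here, the one measured step, a 1.2-fold lower number from compound 2 to compound 1 (0.09 log units; within the scatter), is hydrogen in place of methoxy on an aromatic carbon. Compound 4 `COc1ccc(-c2cc(/C=C/C(=O)c3cc(OC)c(OC)c(OC)c3)[nH]n2)cc1OC` is not yet measured; it differs from compound 3 by hydrogen in place of methoxy on an aromatic carbon, a change of the same kind as the earlier one but not the same, since here the place is also meta to a methoxy group. For compound 4 the expected step is a 1.2-fold higher number from compound 3 to compound 4 (0.08 log units; within the scatter), because the step of a 1.2-fold lower number from compound 2 to compound 1 (0.09 log units; within the scatter) stayed within the scatter. For compound 4 the estimated value is 3200 nM, with a range from 1300 nM to 8000 nM.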

Compound 4, concentration for total growth inhibition: 3160 nM
Beside the measured number, compound 4's estimate is 1.0-fold (0.01 log units) above it; the range from low to high includes it.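

In this assay, hydrogen in place of methoxy on an aromatic carbon gives a 1.2-fold higher number from compound 3 to compound 4 (0.07 log units; within the scatter), so the change again leaves the number within the scatter. Set beside the earlier step, the two cores do not separate: the same change on two cores in this assay, a 1.2-fold lower number (0.09 log units; within the scatter) from compound 2 to compound 1 and a 1.2-fold higher number (0.07 log units; within the scatter) from compound 3 to compound 4, 1.4-fold (0.16 log units) apart, within the scatter of two such steps. This supports carrying the change between these two cores with little expected shift in the number, but two small steps give no reliable direction and do not show that the result holds on other cores or at other places.

Still open, as far as these compounds go, is whether a hydroxy group, an ethoxy group or a chlorine atom at this place would give a step beyond the scatter. The same question stands for removing more than one methoxy group at once.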